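Pentyl to 4-Methylphenyl on the Amide Nitrogen

This account rests on a few compounds, and the source may have more. Where it says the series, first, only, none or still open, it means among the compounds named here.

Compound 1 `C=CC1=C(C(=O)NCc2ccccc2)C(c2ccc(OC)cc2)OC1` gives 39500 nM in a functional assay on SW480 cells (Homo sapiens) for cytotoxicity, read by MTT assay, with a stated time of 24 h; a higher number here means a weaker inhibitor, a lower number a stronger inhibitor.
Compound 2 `C=CC1=C(C(=O)Nc2ccc(OCC)cc2)C(c2ccc(OC)cc2)OC1` is reported only as the limit > 100000 nM in this assay.
Compound 3 `C=CC1=C(C(=O)NCCCCC)C(c2ccc(OC)cc2)OC1` is likewise reported only as the limit > 100000 nM in this assay.

Compound 3 therefore stands at the top of what is shown: it is one of the two values sitting at the limit of > 100000 nM in this assay, at which 2 of the 3 values shown sit, with compound 1 the only member of the series that yields a number. Compound 4 `C=CC1=C(C(=O)Nc2ccc(C)cc2)C(c2ccc(OC)cc2)OC1` differs from compound 3 in one place, (4-methylphenyl in place of pentyl on an amide-type nitrogen). Within the data shown here, two measured steps touch this position. Going from the benzyl amide, the change to an aryl amide gives an at least 2.5-fold higher number from compound 1 to compound 2 (0.40 log units; beyond the scatter), and the change to a pentyl amide gives an at least 2.5-fold higher number from compound 1 to compound 3 (0.40 log units; beyond the scatter). The direct comparison between the two weaker compounds, a step that the two limits leave unreadable from compound 2 to compound 3, cannot be read, since both sit at the limit. Compound 4 carries an aryl group on the amide nitrogen, as compound 2 does, and compound 2 is at the limit. The step that the limit leaves unreadable from compound 3 to compound 4 is expected to be unreadable in the same way. Compound 4 is estimated at 150000 nM, with a range from 50000 nM to 500000 nM, most probably reported again as a limit.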

Compound 4, half-maximal inhibitory concentration: > 100000 nM
Compound 4: a limit, no number; the forecaster's own chance of this, stated with the estimate: 75%; the middle value does not contradict the limit.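

In this assay, 4-methylphenyl in place of benzyl on the amide-type nitrogen gives an at least 2.5-fold higher number from compound 1 to compound 4 (0.40 log units; beyond the scatter), so a second aryl amide, after compound 2, falls on the weaker side of compound 1. The steps to compound 4 from compound 2 and from compound 3 cannot be read, so neither methyl in place of ethoxy on the aromatic carbon nor 4-methylphenyl in place of pentyl on the amide-type nitrogen can be given a size. Among the compounds shown, only the benzyl amide, compound 1, yields a number, and each of the aryl and pentyl amides stops at the same limit: the limit of > 100000 nM in this assay, at which 3 of the 4 values shown sit.

As far as these compounds go, whether another group on the amide-type nitrogen, such as 2-phenylethyl or 4-methylbenzyl, would also give a number in this assay stays open, as does how far the benzyl result can be improved. Also open, from the compounds shown here alone, is how much the value of compound 1 depends on the rest of the shared core, which is the same in all four compounds.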